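Vinyl to 2-hydroxyethyl on the sulfonyl chain

A few compounds are considered here, and "the series" means these few. Any claim that something is new, unique, unknown or untested is made for them only; others in the source may bear on it.

- compound 1 `C=CCCCCCCCS(=O)(=O)/C=C/c1ccc(O)c(O)c1`: 6900 nM
- compound 2 `O=S(=O)(/C=C/c1ccc(O)c(O)c1)CC1CCCCO1`: 10800 nM

Both values come from a functional assay, read by fluorescence and spectrophotometry, with a stated time of 1 h; on this read-out lower numbers stand for an effect already at smaller amounts and higher numbers for an effect only at larger amounts of compound. Compound 1, at 6900 nM, has only compound 2 for comparison, and the two values lie within the usual scatter of each other. Compound 3 `O=S(=O)(/C=C/c1ccc(O)c(O)c1)CCCCCCCCCO` has not yet been measured. It differs from compound 1 as follows: 2-hydroxyethyl in place of vinyl on a saturated chain carbon, seven bonds along the chain from a sulfonyl sulfur. This places 2-hydroxyethyl in place of vinyl on a saturated chain carbon, seven bonds along the chain from a sulfonyl sulfur. Among the measured compounds shown here, no measured pair tests this change, so the only guide is that compound 2, at 10800 nM, stays within the scatter of compound 1 despite its different chain. In this assay a small shift towards a higher number is expected, not beyond the scatter, as a 1.4-fold higher number from compound 1 to compound 3 (0.16 log units; within the scatter). For compound 3 the estimated value is 10000 nM, with an expected range of 4000 nM to 25000 nM.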

Compound 3, half-maximal effective concentration: 7500 nM
Compound 3: middle estimate off by 1.3-fold (0.12 log units), on the high side; the measured number falls inside the stated range.
By their numbers in this assay, from the lowest: compounds 1, 3 and 2 (each within the scatter of the next).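

In this assay, 2-hydroxyethyl in place of vinyl on a saturated chain carbon, seven bonds along the chain from a sulfonyl sulfur, gives a 1.1-fold higher number from compound 1 to compound 3 (0.04 log units; within the scatter). Among the compounds shown here, this is the first pair to test a single change at this position, and it shows that a group with one hydrogen-bond donor and one hydrogen-bond acceptor can replace one with neither without a step beyond the scatter. No supporting measurement bears on this result.

Going by these compounds, whether an amine, a carboxylic acid or a longer chain at this position would give a step beyond the scatter remains open. The three compounds also share the same core, so they leave open how changes to that core would read in this assay.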